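A few compounds are considered here, and "the series" means these few. Any claim that something is new, unique, unknown or untested is made for them only; others in the source may bear on it.

Measured in an ADME assay on HEK293 cells (Homo sapiens) for cytotoxicity, with a stated time of 72 h; a higher number here means that more compound is needed for the effect, a lower number that less compound is needed:
- compound 1 `CCc1ccc(NC(=O)Nc2cc(C)nc3ccccc23)cc1`: 16000 nM
- compound 2 `Cc1cc(NC(=O)Nc2ccc(F)cc2)c2ccccc2n1`: > 25000 nM (a limit)
- compound 3 `Cc1cc(NC(=O)Nc2ccc(O)cc2)c2ccccc2n1`: > 25000 nM (a limit)

Compound 3 has no number, only the limit > 25000 nM. Most of the series sits at this same point: the limit of > 25000 nM in this assay, at which 2 of the 3 values shown sit. Going by the values given here, compound 1 is the only one with a number.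

Compound 4 `Cc1cc(NC(=O)Nc2ccc(N)cc2)c2ccccc2n1` carries amino in place of hydroxy on an aromatic carbon, para to a large group: amino in place of hydroxy on an aromatic carbon.

Among the compounds with values here, three measured steps bear on this change. The nearest is at the same place, hydroxy in place of fluoro, and it is a step that the two limits leave unreadable from compound 2 to compound 3. The two replacements of ethyl at that place give an at least 1.5-fold higher number from compound 1 to compound 2 (0.19 log units; that floor lies within the scatter) and an at least 1.5-fold higher number from compound 1 to compound 3 (0.19 log units; that floor lies within the scatter). Within the data shown here, neither shows a change beyond the scatter, and no measured compound carries the amino group.

With a step that the two limits leave unreadable from compound 2 to compound 3 as the nearest evidence, no step beyond the scatter is expected in this assay. Any number that does appear would be expected to lie somewhat under the limit, close to the value of compound 1. The estimated step is an at least 1.1-fold lower number from compound 3 to compound 4 (0.05 log units; that floor lies within the scatter). For compound 4 the expected value is 22000 nM, with an estimated range of 9000 nM to 35000 nM.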

Compound 4, half-maximal effective concentration: > 25000 nM
Compound 4 was reported as a limit (the forecaster's own chance of this, stated with the estimate: 55%); middle value at least 1.1-fold (0.05 log units) from the limit.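

In this assay compound 4 gives > 25000 nM, which is a limit and not a number, so amino now stands with fluoro and hydroxy at this place without a readable value. Going by these compounds alone, the steps to compound 4 from compound 2 and from compound 3 cannot be read, as both ends are limits, and the only readable step is an at least 1.5-fold higher number from compound 1 to compound 4 (0.19 log units; that floor lies within the scatter). A third replacement of ethyl at this place, para to a large group, therefore leaves the series at one point: the limit of > 25000 nM in this assay, at which 3 of the 4 values shown sit.

Compound 1 remains the only compound with a number, and the floor of each of its steps lies within the scatter, so no change at this position is yet shown to go beyond it. Going by these compounds, it stays open whether a longer chain such as propyl, or a methoxy group, in place of the amino would give a number under the limit, and whether the amino, hydroxy and fluoro compounds differ from one another at all.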